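The compounds below may be only part of what the source reports. "The series", "measured", "known", "first", "only" and "open" are said of these compounds alone.

Measured compounds:
- compound 1, `C=C1[C@H](O)[C@@H](OC(=O)C(C)(C)C)[C@@H](O)C(C)(C)/C=C/[C@H](C)[C@H](OC(=O)c2ccccc2)[C@@]2(O)C[C@@](C)(O)[C@H](OC(C)=O)[C@@H]2[C@H]1OCC(C)C`: 64200 nM
- compound 2, `C=C1[C@H](O)[C@@H](OC(=O)c2cccc(C)c2)[C@@H](O)C(C)(C)/C=C/[C@H](C)[C@H](OC(=O)c2ccccc2)[C@@]2(O)C[C@@](C)(O)[C@H](OC(C)=O)[C@@H]2[C@H]1OCC(C)C`: 7640 nM
- compound 3, `C=C1[C@H](OC(C)=O)[C@@H](OC(C)=O)[C@@H](OC(C)=O)C(C)(C)/C=C/[C@H](C)[C@H](OC(=O)c2ccccc2)[C@@]2(O)C[C@@](C)(OC(=O)C(C)(C)C)[C@H](OC(C)=O)[C@@H]2[C@H]1OCC(C)C`: 500 nM

In a functional assay on NCI/ADR-RES cells (Homo sapiens) for positive allosteric modulation, read by MTT assay, with a stated time of 48 h, tested at 10 uM (on this read-out lower numbers stand for stronger inhibition and higher numbers for weaker inhibition), compound 1 gives 64200 nM and compound 2 gives 7640 nM. The two differ by one change, (3-methylphenyl in place of tert-butyl on a carbonyl carbon), and the step is an 8.4-fold lower number from compound 1 to compound 2 (0.92 log units; beyond the scatter). Compound 3 sits on a core that differs from that of compound 1 in several places, and the difference between the two cores is not broken down here. In this assay compound 3 gives 500 nM, the lowest number of the three measured, beyond the scatter from both compound 2 and compound 1.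

Compound 4, `C=C1[C@H](OC(C)=O)[C@@H](OC(C)=O)[C@@H](OC(C)=O)C(C)(C)/C=C/[C@H](C)[C@H](OC(=O)c2ccccc2)[C@@]2(O)C[C@@](C)(OC(=O)c3cccc(C)c3)[C@H](OC(C)=O)[C@@H]2[C@H]1OCC(C)C`, has not been measured. It differs from compound 3 by 3-methylphenyl in place of tert-butyl on a carbonyl carbon, the same change that separates compound 1 from compound 2, with the same place description around the carbonyl carbon. Among the compounds with values here, only one measured instance of this change exists, and it sits on a different core, so the transfer is uncertain. The expectation is that compound 4 moves in the same direction as that single precedent, since from compound 1 to compound 2 the step was an 8.4-fold lower number from compound 1 to compound 2 (0.92 log units; beyond the scatter), but with a wider range in case the step does not carry over in full on the core of compound 3. The estimated step is a 4.2-fold lower number from compound 3 to compound 4 (0.62 log units; beyond the scatter). Compound 4 is expected at about 120 nM in this assay, within 25 nM to 600 nM.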

Compound 4, half-maximal inhibitory concentration: 1510 nM
For compound 4 the middle estimate is 13-fold (1.10 log units) below the measured one, outside the stated range (above it).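

In this assay, 3-methylphenyl in place of tert-butyl on a carbonyl carbon gives a 3.0-fold higher number from compound 3 to compound 4 (0.48 log units; beyond the scatter), so the change does not keep its direction when carried from the core of compound 1 to the core of compound 3: the same change on two cores in this assay, an 8.4-fold lower number (0.92 log units; beyond the scatter) from compound 1 to compound 2 and a 3.0-fold higher number (0.48 log units; beyond the scatter) from compound 3 to compound 4, 25-fold (1.40 log units) apart, beyond the scatter of two such steps A step measured on one of these cores is therefore a poor guide to the same change on the other, even with the same surroundings at the carbonyl carbon. This does not show which of the several differences between the two cores sets the sign of the step, and two instances give no rule for any further core in the series.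

Within the data shown here, open is whether a carbonyl carrying a longer alkyl chain, an amine or a carboxylic acid would track the step from compound 1 to compound 2 or the one from compound 3 to compound 4. Also open, as far as these compounds go, is whether a core differing from that of compound 3 in only one place, such as a free hydroxyl in place of one acetate, would be enough to reverse the step.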